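Swapping a Dimethoxyphenyl for Furan on the Shared Core

This account rests on a few compounds, and the source may have more. Where it says the series, first, only, none or still open, it means among the compounds named here.

Compound 2 `COc1cc(Cc2cc(C)nn(CC(=O)Nc3ccc(Br)cc3)c2=O)cc(OC)c1` gives in a functional assay on HL-60 cells (Homo sapiens), read by calcium flux (on this read-out higher numbers stand for an effect only at larger amounts of compound and lower numbers for an effect already at smaller amounts), only a limit, > 50000 nM. Compound 1 `Cc1cc(Cc2cccc(F)c2)c(=O)n(CC(=O)Nc2ccc(Br)cc2)n1` likewise reaches only a limit in this assay, namely > 50000 nM. The step that the two limits leave unreadable from compound 1 to compound 2 stays unreadable because the limit of > 50000 nM in this assay, at which 2 of the 2 values shown sit, caps both values. Compound 3 `Cc1cc(Cc2ccoc2)c(=O)n(CC(=O)Nc2ccc(Br)cc2)n1` differs from compound 2 by furan-3-yl in place of 3,5-dimethoxyphenyl on a saturated chain carbon bound to an aromatic carbon. Among the measured compounds shown here, no measured step gives a readable size for such a swap, so the expected step of a number no higher from compound 2 to compound 3 (the limit leaves the size open) in this assay cannot be placed in either direction beyond the scatter. Compound 3 is therefore estimated at 50000 nM, with a range from 10000 nM to 200000 nM, and most likely again only a limit.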

Compound 3, half-maximal effective concentration: > 50000 nM
Compound 3: only a limit was reported; the forecaster's own chance of this, stated with the estimate: 85%; the middle value sits exactly at the limit.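

The steps among compound 1, compound 2 and compound 3 cannot be read, because all three stop at a limit and not at a number: the limit of > 50000 nM in this assay, at which 3 of the 3 values shown sit.

From the compounds shown here alone, whether any other group at this place on the shared core would give a readable value in this assay stays open.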